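The source may hold more compounds than are shown below. What is called first, only, known or untested is meant among the compounds shown, and "the series" means these compounds.

In an ADME assay on a cell-free system (plasma, Rattus norvegicus), with a stated time of 60 min (a higher number here means that more of the compound is left, a lower number that less of the compound is left), the measured compounds give these values.

- compound 1 `O=C(O)c1cc(-c2cccc(COc3ccc4c(=O)n(C5CCCC5)oc4c3)c2)ccc1Cl` gives 100%
- compound 2 `CC(C)N1Cc2cc(OCc3cccc(-c4ccc(Cl)c(C(=O)O)c4)c3)ccc2C1=O` gives 98%
- compound 3 `CC(C)CN1Cc2cc(OCc3cccc(-c4ccc(Cl)c(C(=O)O)c4)c3)ccc2C1=O` gives 99%

The value of compound 2 lies within the scatter of the values of compound 1 and compound 3, so these three compounds cannot be told apart in this assay. Compound 4 `O=C(O)c1cc(-c2cccc(COc3ccc4c(c3)CN(C3CCCCC3)C4=O)c2)ccc1Cl` has not yet been measured. It departs from compound 2 by a single change, which places cyclohexyl in place of isopropyl on an amide-type nitrogen in a ring. Among the compounds with values here, one measured step bears on this position. With isobutyl in place of isopropyl on the same nitrogen, the result was a number 1 percentage points higher from compound 2 to compound 3 (within the scatter). Within the data shown here, that is the only evidence at this position, and no cyclohexyl compound has been measured on this core. No step beyond the scatter is therefore expected in this assay, and no direction can be assigned. The estimated step is no change at the digits printed from compound 2 to compound 4 (within the scatter). For compound 4 the expected value is 98%, with an estimated range from 90% to 100%.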

Compound 4, percent of the compound remaining: 99%
Estimate against measurement, compound 4: 1 percentage points below, and the stated range covers the measured number.
By their numbers in this assay, from the lowest: compounds 2, 3, 4 and 1 (each within the scatter of the next).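

The earlier compounds shown here carried only open chains on the amide-type nitrogen in a ring, and compound 4 extends the comparison to a group with its own ring, a six-membered non-aromatic ring of carbon only. In this assay, cyclohexyl in place of isopropyl gives a step within the scatter (a number 1 percentage points higher from compound 2 to compound 4 (within the scatter)), and so does cyclohexyl in place of isobutyl (no change at the digits printed from compound 3 to compound 4 (within the scatter)), so isopropyl, isobutyl and cyclohexyl cannot be told apart at this position. Nothing available explains this result.

The compounds shown leave open whether an amine or a carboxylic acid carried on the group at this nitrogen would give a value beyond the scatter. They also leave open how a methyl ester in place of the carboxylic acid on the shared core would behave in this assay.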